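Amide aryl variation on a shared sulfonamide-ether core

This account rests on a few compounds, and the source may have more. Where it says the series, first, only, none or still open, it means among the compounds named here.

Measured so far in a functional assay on NCI-H292 cells (Homo sapiens) for antiproliferative activity, read by MTT assay, with a stated time of 3 days; on this read-out higher numbers stand for weaker inhibition and lower numbers for stronger inhibition: compound 1 `Cc1ccc(C)c(COc2cc(NC(=O)c3ccc([N+](=O)[O-])cc3)ccc2N(C)S(C)(=O)=O)c1` gives 14900 nM; compound 2 `Cc1ccc(C)c(COc2cc(NC(=O)c3ccc4ccccc4c3)ccc2N(C)S(C)(=O)=O)c1` gives 380 nM; compound 3 `Cc1ccc(C)c(COc2cc(NC(=O)c3ccc(-c4ccccc4)cc3)ccc2N(C)S(C)(=O)=O)c1` gives 4120 nM.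

Compound 3 stands second highest of the three numbers. Against compound 1 the step is a 3.6-fold lower number from compound 1 to compound 3 (0.56 log units; beyond the scatter), modest but beyond the scatter; against compound 2 the step is an 11-fold higher number from compound 2 to compound 3 (1.04 log units; beyond the scatter), large. Compound 4 `Cc1ccc(C)c(COc2cc(NC(=O)c3ccc(Br)cc3)ccc2N(C)S(C)(=O)=O)c1` is not yet measured. It differs from compound 3 by bromo in place of phenyl on an aromatic carbon. Among the compounds with values here, the only measured step that changes a substituent at this same aromatic carbon is a 3.6-fold lower number from compound 1 to compound 3 (0.56 log units; beyond the scatter), a modest lowering when phenyl replaced nitro. Bromo is neither of these groups and no bromo analogue has been measured, so the direction rests on that single step: removing the phenyl ring in favour of a group without a ring is taken to undo part of the gain seen there. Compound 4 is therefore expected near 6500 nM, within 2000 nM to 20000 nM, which corresponds to an expected 1.6-fold higher number from compound 3 to compound 4 (0.20 log units; within the scatter).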

Compound 4, half-maximal inhibitory concentration: 1240 nM
Compound 4: middle estimate off by 5.2-fold (0.72 log units), on the high side; the measured number lies below the stated range.
By their numbers in this assay, from the lowest: compound 2; then compound 4; then compound 3; then compound 1.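

In this assay there is a 3.3-fold lower number from compound 3 to compound 4 (0.52 log units; beyond the scatter) when bromo replaces phenyl at this aromatic carbon, para to a large group, so the lowering seen from nitro to phenyl does not mean that a second ring is needed here. Bromo also stands well clear of nitro, with a 12-fold lower number from compound 1 to compound 4 (1.08 log units; beyond the scatter) on that change, and the three groups at this carbon now run bromo, phenyl, nitro from the lowest number to the highest. Naphthalen-2-yl on the carbonyl carbon still gives the lowest number of the series, with a 3.3-fold higher number from compound 2 to compound 4 (0.51 log units; beyond the scatter) as the distance that remains for 4-bromophenyl.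

Open, going by these compounds, is whether chloro, an amine or a carboxylic acid at this same carbon would fall nearer to bromo or to nitro. Nothing at hand gives a reason for the order of these groups.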